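Moving the Carboxy Group Around a Pyrrolidine Ring

A few compounds are considered here, and "the series" means these few. Any claim that something is new, unique, unknown or untested is made for them only; others in the source may bear on it.

Measured compounds:
- compound 1, `COc1ccc(/C=C\c2cc(OC)c(OC)c(OC)c2)cc1OCc1ccc(CNC(C)(C)C(=O)O)cc1`: 6500 nM
- compound 2, `COc1ccc(/C=C\c2cc(OC)c(OC)c(OC)c2)cc1OCc1ccc(CN2C[C@H](O)C[C@@H]2C(=O)O)cc1`: > 10000 nM
- compound 3, `COc1ccc(/C=C\c2cc(OC)c(OC)c(OC)c2)cc1OCc1ccc(CN2CCCCC2C(=O)O)cc1`: 3100 nM

All three share one core and differ only in the acid-bearing group on a saturated chain carbon bound to an aromatic carbon. In a functional assay on HepG2 cells (Homo sapiens) for antiproliferative activity, read by CCK-8 assay, with a stated time of 48 h (a lower number here means a stronger inhibitor, a higher number a weaker inhibitor), compound 1 gives 6500 nM. Compound 2 returns only a limit, > 10000 nM, so its true number is not known. Compound 3 gives 3100 nM; the step of an at least 3.2-fold lower number from compound 2 to compound 3 (0.50 log units; beyond the scatter) shows that exchanging the five-membered ring for the six-membered one moves the number downward, and the step of an at least 1.5-fold higher number from compound 1 to compound 2 (0.18 log units; that floor lies within the scatter) reaches at least to the scatter floor, while a 2.1-fold lower number from compound 1 to compound 3 (0.32 log units; beyond the scatter) is a modest gain.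

Compound 4, `COc1ccc(/C=C\c2cc(OC)c(OC)c(OC)c2)cc1OCc1ccc(CN2CC[C@H](C(=O)O)C2)cc1`, keeps the five-membered ring but changes it: 3-carboxypyrrolidin-1-yl in place of 2-carboxy-4-hydroxypyrrolidin-1-yl on a saturated chain carbon bound to an aromatic carbon. The hydroxyl leaves and the acid shifts position. Only compound 2 and compound 3 bear directly on this, and the measured steps suggest the 2-carboxy-4-hydroxypyrrolidin-1-yl group is the weakest of the three. Compound 4 is therefore expected to land lower than the limit of compound 2, by about an at least 1.6-fold lower number from compound 2 to compound 4 (0.22 log units; that floor lies within the scatter), near compound 1, with a real chance that this assay again reports only a limit. The estimate for compound 4 is 6000 nM, between 2500 nM and 15000 nM.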

Compound 4, half-maximal inhibitory concentration: 6400 nM
Estimate against measurement, compound 4: 1.1-fold (0.03 log units) below; the range from low to high includes it.
By their numbers in this assay, from the lowest: compound 3; then compounds 4 and 1 (each within the scatter of the next). At a limit, above all of these: compound 2.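

The step of a 2.1-fold higher number from compound 3 to compound 4 (0.31 log units; beyond the scatter) compares the 2-carboxypiperidin-1-yl group with a five-membered ring that has a real number, and the six-membered ring keeps a modest edge. The step of a 1.0-fold lower number from compound 1 to compound 4 (0.01 log units; within the scatter) shows that the open-chain (1-carboxy-1-methylethyl)amino group and the 3-carboxypyrrolidin-1-yl group cannot be told apart here. The step of an at least 1.5-fold lower number from compound 2 to compound 4 (0.19 log units; that floor lies within the scatter) has a floor within the scatter, and the value for compound 2 is only a limit, so the size of this change remains unsettled: the limit of > 10000 nM in this assay, at which 1 of the 4 values shown sits.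

From the compounds shown here alone, the hydroxyl leaves and the acid shifts in the same change, so their separate contributions stay open, and a 2-carboxypyrrolidin-1-yl group would help to separate them. Going by these compounds, whether the carboxylic acid itself matters also stays open, a question that a methyl ester or a primary amide could address.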